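This account rests on a few compounds, and the source may have more. Where it says the series, first, only, none or still open, it means among the compounds named here.

Working notes on the series. Compound 1 `[N-]=[N+]=NCc1nnc(-c2cc(S(N)(=O)=O)c(SCc3ccccc3)cc2Cl)o1` gives 55000 nM in a functional assay on MCF7 cells (Homo sapiens) for cytotoxicity, read by MTT assay, with a stated time of 72 h; a lower number here means a stronger inhibitor, a higher number a weaker inhibitor. Compound 2 `NCc1nnc(-c2cc(S(N)(=O)=O)c(SCc3ccccc3)cc2Cl)o1` gives 135000 nM in the same assay, and compound 3 `NS(=O)(=O)c1cc(-c2nnc(/C=C/c3ccccc3)o2)c(Cl)cc1SCc1ccccc1` gives 16000 nM. The measured steps are all on the same side of the shared core: a 2.5-fold higher number from compound 1 to compound 2 (0.39 log units; beyond the scatter), a 3.4-fold lower number from compound 1 to compound 3 (0.54 log units; beyond the scatter), and an 8.4-fold lower number from compound 2 to compound 3 (0.93 log units; beyond the scatter). On these numbers compound 3 stands lowest of the three, with compound 1 nearest and compound 2 furthest.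

Compound 4 `NS(=O)(=O)c1cc(-c2nnc(/C=C/c3ccc(Br)cc3)o2)c(Cl)cc1SCc1ccccc1` differs from compound 3 by bromo in place of hydrogen on an aromatic carbon, placed on an aromatic carbon of a six-membered aromatic ring of carbon only, para to a large group; read one bond further out, phenyl becomes 4-bromophenyl and 2-phenylethenyl becomes 2-(4-bromophenyl)ethenyl. Among the measured compounds shown here, none of the three measured steps touches this ring; each of them exchanges the whole group on the other end of the core, so no measured step bears directly on this change. With nothing in the series speaking for a shift, the step is expected to stay within the usual scatter, that is a 1.1-fold lower number from compound 3 to compound 4 (0.03 log units; within the scatter). Compound 4 is therefore estimated at 15000 nM in this assay, with a range from 5000 nM to 45000 nM.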

Compound 4, half-maximal inhibitory concentration: 13000 nM
Compound 4: middle estimate off by 1.2-fold (0.06 log units), on the high side; the measured number falls inside the stated range.
By their numbers in this assay, from the lowest: compounds 4 and 3 (each within the scatter of the next); then compound 1; then compound 2.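

In this assay, among the compounds shown here, the step of a 1.2-fold lower number from compound 3 to compound 4 (0.09 log units; within the scatter) is the first reading on the phenyl ring at the far end of the 2-phenylethenyl group, and it shows that bromo in place of hydrogen, on an aromatic carbon para to a large group, leaves the number within the scatter, so this single change separates compound 3 and compound 4 by nothing that can be read. The exchanges at the other end of the core keep the direction seen with compound 3, with a 10-fold lower number from compound 2 to compound 4 (1.02 log units; beyond the scatter) and a 4.2-fold lower number from compound 1 to compound 4 (0.63 log units; beyond the scatter) placing the 2-(4-bromophenyl)ethenyl group on the low side of both aminomethyl and azidomethyl, and the step from the aminomethyl compound is printed as large. No data on any property of these compounds are available to account for either observation.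

Going by these compounds, whether this position stays as flat with other groups remains open, for example with a methoxy group, an amine or a carboxylic acid in place of bromo. Also open, on these data alone, is how the number responds to a longer chain between the shared core and the phenyl ring.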